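The compounds below may be only part of what the source reports. "The series", "measured", "known", "first", "only" and "open" are said of these compounds alone.

Among the compounds with values here, compound 2 `Cc1cc(O)c(C2=NN(c3ccc(S(N)(=O)=O)cc3)C(/C=C/c3ccccc3)C2)cc1Cl` gives 28400 nM in a functional assay on OVCAR-3 cells (Homo sapiens) for antiproliferative activity, with a stated time of 48 h (a higher number here means a weaker inhibitor of growth, a lower number a stronger inhibitor of growth), the highest of the two numbers so far; compound 1 `Cc1cc(O)c(C2=NN(c3ccc(S(N)(=O)=O)cc3)C(c3ccccc3O)C2)cc1Cl` gives 3730 nM in this assay. The change to compound 3 `COc1ccc(C2CC(c3cc(Cl)c(C)cc3O)=NN2c2ccc(S(N)(=O)=O)cc2)c(OC)c1OC` is 2,3,4-trimethoxyphenyl in place of 2-phenylethenyl on a saturated ring carbon. Within the data shown here, the one measured step that bears on it is the reverse exchange on a saturated ring carbon, a 7.6-fold higher number from compound 1 to compound 2 (0.88 log units; beyond the scatter), where an aryl group gave way to 2-phenylethenyl. Returning an aryl group to that saturated ring carbon is expected to bring the number back down, roughly a 7.1-fold lower number from compound 2 to compound 3 (0.85 log units; beyond the scatter) in this assay. Compound 3 is therefore estimated at 4000 nM in this assay, with a range of 1300 nM to 13000 nM.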

Compound 3, concentration for total growth inhibition: 4770 nM
Compound 3: middle estimate off by 1.2-fold (0.08 log units), on the low side; the range from low to high includes it.
By their numbers in this assay, from the lowest: compounds 1 and 3 (each within the scatter of the next); then compound 2.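

In this assay, 2,3,4-trimethoxyphenyl in place of 2-phenylethenyl on the saturated ring carbon gives a 6.0-fold lower number from compound 2 to compound 3 (0.77 log units; beyond the scatter) on this position, so a second aryl group also stands clear of 2-phenylethenyl. The other comparison is a 1.3-fold higher number from compound 1 to compound 3 (0.11 log units; within the scatter) and separates 2,3,4-trimethoxyphenyl from 2-hydroxyphenyl by no readable margin, so a ring hydroxyl is not needed to reach this level. No evidence on the cause of either step is available. Open, going by these compounds, is whether an aryl ring is needed at this carbon at all, or whether an amine or a short saturated alkyl chain there would give a similar number.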